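Halogenated Chalcone Analogues Assessed for Cytotoxicity in Lung Cells

The source may report more compounds than this note shows. Statements on the series, on what has been measured and on what is new or still open speak of the compounds shown alone.

Measured compounds:
- compound 1, `CNC(=O)c1cc(Oc2ccc(C(=O)/C=C/c3ccco3)cc2)ccn1`: "not determined" (no result reported) in a functional assay on A549 cells (Homo sapiens) for cytotoxicity, read by MTT assay, with a stated time of 72 h; a lower number here means a stronger inhibitor, a higher number a weaker inhibitor
- compound 2, `CNC(=O)c1cc(Oc2ccc(C(=O)/C=C/c3cccc(Br)c3)cc2)ccn1`: 9940 nM
- compound 3, `CNC(=O)c1cc(Oc2ccc(C(=O)/C=C/c3ccc(Cl)cc3Cl)cc2)ccn1`: 9460 nM

Compound 2 holds the highest of the two numbers in this assay, and its nearest neighbour is compound 3, which differs by a 1.1-fold lower number from compound 2 to compound 3 (0.02 log units; within the scatter). Compound 4, `CNC(=O)c1cc(Oc2ccc(C(=O)/C=C/c3cccc(Cl)c3Cl)cc2)ccn1`, has not been measured. Compared with compound 2 it shows the following change: 2,3-dichlorophenyl in place of 3-bromophenyl on a double-bonded chain carbon bound to a double-bonded chain carbon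

For the measured compounds named here, the only step that bears on this change is the one from compound 2 to compound 3, which also places two chlorines on the same ring in place of one bromine and stays within the scatter. Compound 4 is therefore expected to move from compound 2 by a 1.1-fold lower number from compound 2 to compound 4 (0.04 log units; within the scatter), no further than the scatter allows. The estimated value for compound 4 in this assay is 9000 nM, within 4000 nM to 20000 nM.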

Compound 4, half-maximal inhibitory concentration: > 50000 nM
Compound 4: a limit, no number; the forecaster's own chance of this, stated with the estimate: 10%; at least 5.5-fold (0.74 log units) between middle value and limit.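

Compound 4 carries a limit and not a number in this assay: the limit of > 50000 nM in this assay, at which 1 of the 4 values shown sits. Even so, this position on a double-bonded chain carbon bound to a double-bonded chain carbon proves sensitive to the change, with an at least 5.0-fold higher number from compound 2 to compound 4 (0.70 log units; beyond the scatter), whereas the earlier step between compound 2 and compound 3 stayed within the scatter. The two dichlorophenyl groups also part, with an at least 5.2-fold higher number from compound 3 to compound 4 (0.72 log units; beyond the scatter), so here the chlorine pattern matters and not just the presence of two chlorines. Open, on these data alone, is whether a methoxy group or an amine on this ring would track compound 3 or compound 4.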